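A few compounds are considered here, and "the series" means these few. Any claim that something is new, unique, unknown or untested is made for them only; others in the source may bear on it.

Compound 1 `COc1cccc(CNCCCNc2ccnc3cc(Oc4ccc(C(C)(C)C)cc4)ccc23)c1O`: 317 10^-6 cm/s
Compound 2 `COc1ccc(F)cc1CNCCCNc1ccnc2cc(-c3cccc4ccccc34)ccc12`: 237 10^-6 cm/s

In an ADME assay for permeability, using PAMPA, with a stated time of 30 min, at pH 7.4 (a higher number here means that the compound crosses the layer faster, a lower number that the compound crosses the layer more slowly), compound 2 gives 237 10^-6 cm/s, and in this assay compound 1 gives 317 10^-6 cm/s; the two numbers lie within the usual scatter of one another, so neither can be called faster. Compound 3 `COc1cccc(CNCCCNc2ccnc3cc(-c4cccc5ccccc45)ccc23)c1O` differs from compound 2 by one change: 2-hydroxy-3-methoxyphenyl in place of 5-fluoro-2-methoxyphenyl on a saturated chain carbon bound to an amine nitrogen. Among the compounds with values here, no measured pair shows this exact step, yet compound 1 already carries the entering group. The step from compound 2 to compound 3 is expected to stay within the scatter, because with that same group compound 1 gives 317 10^-6 cm/s. Compound 3 is therefore estimated at 260 10^-6 cm/s, expected between 150 10^-6 cm/s and 420 10^-6 cm/s, a step of a 1.1-fold higher number from compound 2 to compound 3 (0.04 log units; within the scatter).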

Compound 3, apparent permeability: 237 10^-6 cm/s
For compound 3 the middle estimate is 1.1-fold (0.04 log units) above the measured one; low and high end bracket the measured number.
By their numbers in this assay, from the lowest: compounds 2, 3 and 1 (each within the scatter of the next).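

In this assay, 2-hydroxy-3-methoxyphenyl in place of 5-fluoro-2-methoxyphenyl on a saturated chain carbon bound to an amine nitrogen gives no change at the digits printed from compound 2 to compound 3 (within the scatter), so this exchange leaves the read-out unmoved at this position. With that group held constant, naphthalen-1-yl in place of 4-(tert-butyl)phenoxy on an aromatic carbon gives a 1.3-fold lower number from compound 1 to compound 3 (0.13 log units; within the scatter), so this second exchange also shows no clear change. Nothing given here explains either result. From the compounds shown here alone, whether a carboxylic acid in place of either aromatic group, or a longer chain bound to the amine nitrogen, would move the number remains open.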